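Swapping the aryl sulfonyl group in an indazole sulfonamide

The source may report more compounds than this note shows. Statements on the series, on what has been measured and on what is new or still open speak of the compounds shown alone.

Compound 1 `CC(=O)NCc1cccc(Cn2nc(NS(=O)(=O)c3ccc(Cl)s3)c3c(F)cccc32)c1`: 79.4 nM
Compound 2 `COc1cccc2c1c(NS(=O)(=O)c1ccc(Cl)c(Cl)c1)nn2Cc1cccc(CNC(=O)C(C)(C)O)c1`: 398 nM

In a functional assay on CHO cells for antagonist activity at C-C chemokine receptor type 4 (Homo sapiens), read by GTPgammaS binding (a lower number here means a stronger inhibitor, a higher number a weaker inhibitor), compound 2 gives 398 nM, the higher of the two numbers; compound 1 gives the lower one, and that gap lies beyond the usual scatter. Compound 3 `COc1cccc2c1c(NS(=O)(=O)c1ccc(C)c(F)c1)nn2Cc1cccc(CNC(=O)C(C)(C)O)c1` is not yet measured. It differs from compound 2 in one place: 3-fluoro-4-methylphenyl in place of 3,4-dichlorophenyl on a sulfonyl sulfur. Among the compounds with values here, no measured pair shows this change, so the direction is uncertain; a step from compound 2 to compound 3 within the scatter, or a slightly higher number, is expected, a 1.3-fold higher number from compound 2 to compound 3 (0.10 log units; within the scatter). Compound 3 is estimated at 500 nM, between 160 nM and 1600 nM.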

Compound 3, half-maximal inhibitory concentration in the C-C chemokine receptor type 4 assay: 15.9 nM
Compound 3: the middle estimate sits 31-fold (1.50 log units) above what was measured, outside the stated range (below it).
By their numbers in the C-C chemokine receptor type 4 assay, from the lowest: compound 3; then compound 1; then compound 2.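

Within the data shown here, in the C-C chemokine receptor type 4 assay, 3-fluoro-4-methylphenyl in place of 3,4-dichlorophenyl on the sulfonyl sulfur gives a 25-fold lower number from compound 2 to compound 3 (1.40 log units; beyond the scatter), the first single-place step here. This aryl group therefore has a large bearing on the number, even though both groups have 8 heavy atoms and one aromatic ring. In a physicochemical assay for solubility, read by chemiluminescence, measured as kinetic solubility (on this read-out lower numbers stand for lower solubility and higher numbers for higher solubility), compound 2 gives 76 ug/mL and compound 3 gives 36 ug/mL. The gain comes with lower solubility in the physicochemical assay: the measured solubility of compound 2, 76 ug/mL, and of compound 3, 36 ug/mL, a 2.1-fold lower number (0.32 log units; beyond the scatter)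

The pair cannot separate the methyl from the fluorine, as both enter together. Going by these compounds, how a nitrile or an amine on this ring would behave remains open.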